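Amine replacement at the side chain: solubility notes

The source may report more compounds than this note shows. Statements on the series, on what has been measured and on what is new or still open speak of the compounds shown alone.

Measured so far:
compound 1 `COc1ccc2[nH]c(C(=O)N3CC(=O)N(Cc4ccccc4)[C@@H](CN4[C@H](C)COC[C@@H]4C)C3)cc2c1` — > 100000 nM
compound 2 `COc1ccc2[nH]c(C(=O)N3CC(=O)N(Cc4ccccc4)[C@@H](CN4CC5CCCC5C4)C3)cc2c1` — 20700 nM

In a physicochemical assay for solubility, read by spectrophotometry, in phosphate buffer, with a stated time of 2 h, at pH 7.4 (on this read-out lower numbers stand for lower solubility and higher numbers for higher solubility), compound 1 sits at a limit of the assay, not a number, (the limit of > 100000 nM in this assay, at which 1 of the 2 values shown sits). For the measured compounds named here, compound 2 therefore holds the only numerical value in this assay, giving 20700 nM. Going by the values given here, the one measured step, an at least 4.8-fold lower number from compound 1 to compound 2 (0.68 log units; beyond the scatter), concerns the same position that the next change touches.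

Compound 3 `COc1ccc2[nH]c(C(=O)N3CC(=O)N(Cc4ccccc4)[C@@H](CN4CCc5ccccc5C4)C3)cc2c1` carries the change (a group of 10 heavy atoms (9 carbon, 1 nitrogen; one six-membered non-aromatic ring with 1 hetero atom, one six-membered aromatic ring of carbon only) in place of a group of 8 heavy atoms (7 carbon, 1 nitrogen; one five-membered non-aromatic ring of carbon only, one five-membered non-aromatic ring with 1 hetero atom), on a saturated chain carbon bound to a saturated ring carbon). Among the compounds with values here, only the step from compound 1 to compound 2 bears on it, and it records a change at this position of at least modest size, downward. For compound 3 the expected step is a 2.3-fold lower number from compound 2 to compound 3 (0.36 log units; beyond the scatter), a further decrease in solubility of modest size, as the earlier replacement at this position was also downward. The estimated solubility of compound 3 is 9000 nM, with a range from 3000 nM to 30000 nM.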

Compound 3, solubility: 9000 nM
Beside the measured number, compound 3's estimate shows no gap at the digits printed; the measured number falls inside the stated range.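

In this assay, this position now has a step read between two numbers and not against a limit, with 1,2,3,4-tetrahydroisoquinolin-2-yl on the saturated chain carbon: a 2.3-fold lower number from compound 2 to compound 3 (0.36 log units; beyond the scatter). Taken from 3,5-dimethylmorpholin-4-yl directly to 1,2,3,4-tetrahydroisoquinolin-2-yl, the replacement gives the largest step so far in this short set, an at least 11-fold lower number from compound 1 to compound 3 (1.04 log units; beyond the scatter), and the three compounds now fall in one downward order. That order has an open upper end, as compound 1 stands at a limit and not a number: the limit of > 100000 nM in this assay, at which 1 of the 3 values shown sits.

The compounds shown do not separate the six-membered aromatic ring of compound 3 from the other differences among the three groups, such as the oxygen of 3,5-dimethylmorpholin-4-yl. Also open, from the compounds shown here alone, is how a piperazin-1-yl group, or a group carrying a carboxylic acid, would read on this saturated chain carbon.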